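Furan in place of thiophene on a scaffold without measurable inhibition

A few compounds are considered here, and "the series" means these few. Any claim that something is new, unique, unknown or untested is made for them only; others in the source may bear on it.

In a functional assay on HCT-116 cells (Homo sapiens), read by MTT assay, with a stated time of 72 h (on this read-out lower numbers stand for stronger inhibition and higher numbers for weaker inhibition), compound 1 `Nc1nc(N)c2c(-c3ccsc3)cn([C@@H]3O[C@H](CO)[C@@H](O)[C@H]3O)c2n1` gives > 20000 nM, which is a limit of the assay and not a number. Compound 2 `COc1nc(N)nc2c1c(-c1ccsc1)cn2[C@@H]1O[C@H](CO)[C@@H](O)[C@H]1O` reaches > 20000 nM, again a limit. Compound 3 `Cc1nc(N)c2c(-c3ccsc3)cn([C@@H]3O[C@H](CO)[C@@H](O)[C@H]3O)c2n1` also reaches > 20000 nM, a limit. The steps a step that the two limits leave unreadable from compound 1 to compound 2 and a step that the two limits leave unreadable from compound 1 to compound 3 therefore cannot be read, since all three values sit at the limit of > 20000 nM in this assay, at which 3 of the 3 values shown sit. Compound 4 `Nc1nc(N)c2c(-c3ccoc3)cn([C@@H]3O[C@H](CO)[C@@H](O)[C@H]3O)c2n1` differs from compound 1 by furan-3-yl in place of thiophen-3-yl on an aromatic carbon. Among the measured compounds shown here, no measured step involves this change, and none of the three measured compounds shows inhibition within the reach of the assay. Compound 4 is therefore expected to stay at the limit, with an estimated step that the limit leaves unreadable from compound 1 to compound 4. The estimated value for compound 4 is 30000 nM, within the range 10000 nM to 100000 nM.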

Compound 4, half-maximal inhibitory concentration: > 20000 nM
Compound 4: no number, only a limit (the forecaster's own chance of this, stated with the estimate: 85%); the middle value lies beyond the limit too.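

Compound 1 and compound 4 both give a limit and not a number, so furan-3-yl in place of thiophen-3-yl yields no readable step: the limit of > 20000 nM in this assay, at which 4 of the 4 values shown sit. The compounds shown leave open which change to the shared core, if any, would bring measurable inhibition.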